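This account rests on a few compounds, and the source may have more. Where it says the series, first, only, none or still open, it means among the compounds named here.

Measured in a functional assay on DU-145 cells (Homo sapiens) for cytotoxicity, read by trypan blue exclusion, with a stated time of 96 h; on this read-out lower numbers stand for stronger inhibition and higher numbers for weaker inhibition:
- compound 1 `COc1ccc(N)cc1CS(=O)(=O)/C=C/c1c(OC)cccc1OC`: 25000 nM
- compound 2 `COC(=O)CNc1cc(CS(=O)(=O)/C=C/c2c(OC)cc(OC)cc2OC)ccc1OC`: 100 nM

Compound 2 has the lower of the two numbers, and its gap to compound 1 lies beyond the scatter. Among the compounds with values here, these two compounds differ in more than one place, so no single-change step has been measured.

Compound 3 `COC(=O)C(C)(C)Nc1cc(CS(=O)(=O)/C=C/c2c(OC)cc(OC)cc2OC)ccc1OC` differs from compound 2 at one place: 1-(methoxycarbonyl)-1-methylethyl in place of (methoxycarbonyl)methyl on a nitrogen on an aromatic ring.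

No measurement shows the effect of this change, so the expectation is anchored on compound 2 at 100 nM. A moderate move towards weaker inhibition in this assay is expected, with an estimated size of a 2.0-fold higher number from compound 2 to compound 3 (0.30 log units; within the scatter). The range is kept wide, since compound 1 at 25000 nM shows how far numbers in this series can lie apart. For compound 3 the expected value is 200 nM, with an estimated range of 50 nM to 1500 nM.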

Compound 3, half-maximal inhibitory concentration: 2500 nM
For compound 3 the middle estimate is 13-fold (1.10 log units) below the measured one, and the stated range ends below it.
By their numbers in this assay, from the lowest: compound 2; then compound 3; then compound 1.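

In this assay, within the data shown here, the group on the nitrogen on an aromatic ring proves to be a sensitive place: 1-(methoxycarbonyl)-1-methylethyl in place of (methoxycarbonyl)methyl gives a 25-fold higher number from compound 2 to compound 3 (1.40 log units; beyond the scatter), the first single-change step. The two groups have the same hydrogen-bond donor and acceptor counts and differ only in carbon, so a change confined to carbon at this place is enough to produce a step beyond the scatter. No available data bear on why this step is so large.

Still open, as far as these compounds go, is whether a smaller branch, 1-(methoxycarbonyl)ethyl, would give part of this step, and how a longer chain or a carboxylic acid in place of the methyl ester would read at this nitrogen. The same change on the core of compound 1 is also unresolved.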